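This account rests on a few compounds, and the source may have more. Where it says the series, first, only, none or still open, it means among the compounds named here.

Measured compounds:
compound 1, `CN(c1ccc(Oc2ncnc3sccc23)cc1)c1nccc(N2CCCC2)n1`: 42.2%
compound 2, `CN(c1ccc(Oc2ncnc3sccc23)cc1)c1nccc(N2CCCCC2)n1`: 52.2%
compound 3, `c1cc(N2CCCC2)nc(Nc2ccc(Oc3ncnc4sccc34)cc2)n1`: 54.4%

All numbers come from a functional assay on HCT-116 cells (Homo sapiens) for inhibition, read by MTT assay, with a stated time of 72 h, tested at 20 uM; on this read-out higher numbers stand for more inhibition at the one concentration tested (going by the name of the read-out) and lower numbers for less inhibition. Compound 3 has the highest of the three numbers in this assay; its gap to compound 2 lies within the scatter, while the step of a number 12.2 percentage points higher from compound 1 to compound 3 (beyond the scatter) lies beyond it. Compound 4, `c1ccc2c(c1)CCN2c1ccnc(Nc2ccc(Oc3ncnc4sccc34)cc2)n1`, differs from compound 3 by 2,3-dihydro-1H-indol-1-yl in place of pyrrolidin-1-yl on an aromatic carbon. Within the data shown here, the one measured step on that aromatic carbon is a number 10 percentage points higher from compound 1 to compound 2 (within the scatter), a change of ring size that stayed within the scatter. Among the measured compounds shown here, no measured step covers a group of the size now entering. The step expected from this is therefore a number 2.6 percentage points higher from compound 3 to compound 4 (within the scatter), within the scatter and at most slightly upward. Compound 4 is estimated at 57%, with a range from 40% to 73%.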

Compound 4, a percentage reported as inhibition, at one concentration (the size of the read-out at that concentration, not a potency): -0.62%
Beside the measured number, compound 4's estimate is 57.6 percentage points above it, outside the stated range (below it).
By their numbers in this assay, from the lowest: compound 4; then compounds 1, 2 and 3 (each within the scatter of the next, the first and the last beyond it).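

Among these compounds, on this assay the aromatic carbon of the six-membered ring with 2 nitrogen proves far less permissive than the earlier compounds suggested: 2,3-dihydro-1H-indol-1-yl in place of pyrrolidin-1-yl gives a number 55 percentage points lower from compound 3 to compound 4 (beyond the scatter) and leaves compound 4 with no meaningful inhibition at the tested concentration. The ring-size step from pyrrolidin-1-yl to piperidin-1-yl gave no hint of a loss this large. Nothing measured here accounts for the drop.

Open, going by these compounds, is whether the added carbon-only aromatic ring itself or the larger group as a whole carries the loss. An N-methylanilino group or morpholin-4-yl at this carbon would help to separate the two.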